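Replacing Phenyl with Naphthalen-2-yl on Compound 2

The source may hold more compounds than are shown below. What is called first, only, known or untested is meant among the compounds shown, and "the series" means these compounds.

In a toxicity assay on THP-1 cells (Homo sapiens) for cytotoxicity, read by luminescence and CellTiter-Glo, with a stated time of 72 h (on this read-out higher numbers stand for lower toxicity in this test and lower numbers for higher toxicity in this test), compound 1 `CN1CCN(c2ccc(Nc3nccc(-c4cccc(Cl)c4)n3)cc2C(F)(F)F)CC1` gives 5280 nM and compound 2 `CN1CCN(c2ccc(Nc3nccc(-c4ccccc4)n3)cc2C(F)(F)F)CC1` gives 4100 nM. Among the compounds with values here, these two numbers lie within the scatter of each other, so compound 2 holds no distinct place on the values measured so far. Compound 3 `CN1CCN(c2ccc(Nc3nccc(-c4ccc5ccccc5c4)n3)cc2C(F)(F)F)CC1` has naphthalen-2-yl in place of phenyl on an aromatic carbon. Within the data shown here, only one measured step bears on this change, and it concerns the same phenyl group: a 1.3-fold lower number from compound 1 to compound 2 (0.11 log units; within the scatter). That step exchanges a chloro group for hydrogen and does not add a second ring, so it is only a loose guide to the new change. Among the measured compounds shown here, no measured compound carries a group of this size, which leaves the estimate wide. On the evidence of that one small step, no shift beyond the scatter in this assay is expected. The expected step is a 1.3-fold lower number from compound 2 to compound 3 (0.11 log units; within the scatter), and any lean towards a lower number is tentative. For compound 3 the estimated value is 3200 nM, with an expected range from 1300 nM to 7500 nM.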

Compound 3, half-maximal cytotoxic concentration: 3040 nM
For compound 3 the middle estimate is 1.1-fold (0.02 log units) above the measured one; measured number inside the range.
By their numbers in this assay, from the lowest: compounds 3, 2 and 1 (each within the scatter of the next).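

In this assay, adding a second six-membered aromatic ring of carbon only at this position gives a 1.3-fold lower number from compound 2 to compound 3 (0.13 log units; within the scatter). Against the 3-chlorophenyl group, the same position gives a 1.7-fold lower number from compound 1 to compound 3 (0.24 log units; within the scatter), so the earlier small exchange of chloro for hydrogen now has a counterpart in a group with more heavy atoms, and neither change leaves the scatter. Across phenyl, 3-chlorophenyl and naphthalen-2-yl, this position therefore shows no step that can be told from the scatter in this test, and nothing available here accounts for that result.

All three groups are aromatic and made of carbon apart from the chloro substituent, so the compounds shown leave open what an amine, a carboxylic acid or a longer alkyl chain would do at this position. They also share the rest of the core, including the trifluoromethyl group, and so leave open whether a change elsewhere on the core would give a step beyond the scatter.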